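One Added Methyl on the Higher-Value Compound

A few compounds are considered here, and "the series" means these few. Any claim that something is new, unique, unknown or untested is made for them only; others in the source may bear on it.

Compound 1 `CCC1C(=O)N(C)c2cnc(-n3ccc4cc(C(=O)NC)ccc43)nc2N1c1ccn(C)n1` gives 43100 nM
Compound 2 `CCCCNS(=O)(=O)c1ccc(Nc2ncc3c(n2)N(C2CCCC2)[C@H](CC)C(=O)N3C)cc1` gives 477 nM

Both compounds were tested in a functional assay on A549 cells (Homo sapiens) for antiproliferative activity, read by CCK-8 assay, with a stated time of 72 h; on this read-out lower numbers stand for stronger inhibition of growth and higher numbers for weaker inhibition of growth. Compound 1, at 43100 nM, stands at the top of the two numbers, so it is the weaker inhibitor of growth. Compound 2, at 477 nM, lies far lower, and that gap is well beyond the usual scatter of repeat measurements. The two compounds differ in several places, so their gap cannot be tied to any single change.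

Compound 3 `CCNC(=O)c1ccc2c(ccn2-c2ncc3c(n2)N(c2ccn(C)n2)C(CC)C(=O)N3C)c1` is a much closer relative of compound 1. The change is methyl in place of hydrogen on a saturated chain carbon bound to an amide-type nitrogen, which turns methylcarbamoyl into ethylcarbamoyl. Within the data shown here, no measured pair shows this change, so the expectation rests only on compound 1 at 43100 nM and on how small the change is. The expected step is a 1.2-fold lower number from compound 1 to compound 3 (0.09 log units; within the scatter), a slight move to a lower number that should not exceed the scatter. In this assay, compound 3 is expected at 35000 nM, with an estimated range of 12000 nM to 100000 nM.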

Compound 3, concentration for 50% growth inhibition: 21700 nM
The estimate for compound 3 lay 1.6-fold (0.21 log units) above the measured number; measured number inside the range.
By their numbers in this assay, from the lowest: compound 2; then compounds 3 and 1 (each within the scatter of the next).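

In this assay, among these compounds, this is the first measured pair at this position, and it gives a 2.0-fold lower number from compound 1 to compound 3 (0.30 log units; within the scatter). The added methyl, which turns methylcarbamoyl into ethylcarbamoyl, therefore produces a difference that cannot be told apart from ordinary variation between repeat measurements. On this core, then, a saturated chain carbon bound to an amide-type nitrogen can carry this one extra carbon with no clear effect on the growth read-out, although a single pair cannot show more than that, and no measurement at hand offers an explanation for this result.

Going by these compounds, whether a longer chain such as propyl, or a chain ending in an amine or a carboxylic acid, would also stay within the scatter remains open. The two compounds in this pair also share the same core and the same methyl-bearing pyrazole group, so it is equally unknown whether changing methylcarbamoyl to ethylcarbamoyl would give a similarly small step on a different core.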